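The source may report more compounds than this note shows. Statements on the series, on what has been measured and on what is new or still open speak of the compounds shown alone.

Of the compounds shown here, two sharing one core have been measured in a functional assay on the whole organism (Tail, strain ICR) with Mus musculus as the target, in the tail flick test, with a stated time of 60 min, at a dose of 25 umol/kg by the oral route; on this read-out higher numbers stand for a stronger effect at the one dose given and lower numbers for a weaker effect. Compound 1 `C[C@@H](O)[C@H](NC(=O)CN(c1nc(Cl)nc2[nH]cnc12)C1CC1)C(=O)O` bears a carboxy group; in this assay compound 1 gives 30.1%. Compound 2 `CSCC[C@H](NC(=O)CN(c1nc(Cl)nc2[nH]cnc12)C1CC1)C(=O)OCc1ccccc1` bears a benzyloxycarbonyl group in that place; in this assay compound 2 gives 30.8%. These two values lie within the usual scatter of each other, so compound 2 stands level with compound 1 rather than apart from it. Compound 3 `CSCC[C@H](NC(=O)CN(c1nc(Cl)nc2[nH]cnc12)C1CC1)C(=O)O` has not yet been measured. It differs from compound 2 by hydrogen in place of benzyl on an oxygen next to a carbonyl group. Within the data shown here, no pair of measured compounds differs in exactly this place, so the size of the step cannot be read off and has to be expected. Compound 1 already gives 30.1% with a carboxy group in that place, which is the ground for the expectation that follows. The step expected in this assay is a number 0.8 percentage points lower from compound 2 to compound 3 (within the scatter), none beyond the scatter. Compound 3 is therefore estimated at 30%, with a range from 15% to 45%.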

Compound 3, a percentage reported as activity, at one dose (the size of the read-out at that dose, not a potency): 22.8%
Compound 3: middle estimate off by 7.2 percentage points, on the high side, within the range that was stated.
By their numbers in this assay, from the lowest: compounds 3, 1 and 2 (each within the scatter of the next).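

Putting hydrogen in place of benzyl on an oxygen next to a carbonyl group gives a number 8 percentage points lower from compound 2 to compound 3 (within the scatter) in this assay and so does not separate the benzyloxycarbonyl group from the carboxy group at this one dose. The side chain can now be read as well: 2-(methylsulfanyl)ethyl in place of 1-hydroxyethyl on a saturated chain carbon bound to an amide-type nitrogen and a carbonyl carbon gives a number 7.3 percentage points lower from compound 1 to compound 3 (within the scatter) and leaves these two compounds equally unseparated. Nothing measured here explains either step.

On these data alone, whether a methyl ester or a primary amide in place of the carboxy group, or a longer chain in place of 2-(methylsulfanyl)ethyl, would move the read-out beyond the scatter remains open. A single dose also leaves the potency of all these compounds unknown.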